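The compounds below may be only part of what the source reports. "The series", "measured", "known", "first", "only" and "open" are said of these compounds alone.

Notes on the amide series around compound 1 `COc1cc(OC)c(Cl)c(-c2ccc3c(NC(=O)c4ccc(N5CCN(C)CC5)cc4)n[nH]c3n2)c1Cl`. Going by the values given here, in a functional assay on NCI-H1581 cells (Homo sapiens) for antiproliferative activity, read by CCK-8 assay, with a stated time of 72 h (on this read-out higher numbers stand for weaker inhibition and lower numbers for stronger inhibition), compound 1 gives 1.7 nM, the second highest of the three numbers so far, though the nearest neighbour sits within the scatter: compound 3 `COc1cc(OC)c(Cl)c(-c2ccc3c(NC(=O)c4ccc(N5CCN(C(C)C)CC5)cc4)n[nH]c3n2)c1Cl` gives 1.4 nM, and the step of a 1.2-fold lower number from compound 1 to compound 3 (0.08 log units; within the scatter) is not a real difference. Among the compounds with values here, the one large movement is compound 2 `COc1cc(OC)c(Cl)c(-c2ccc3c(NC(=O)c4ccc(N5CCCCC5)cc4)n[nH]c3n2)c1Cl`, which gives 558 nM, with a 330-fold higher number from compound 1 to compound 2 (2.52 log units; beyond the scatter) and, in the other direction, a 400-fold lower number from compound 2 to compound 3 (2.60 log units; beyond the scatter).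

Compound 4 `COc1cc(OC)c(Cl)c(-c2ccc3c(NC(=O)c4ccc(N(C)CCN(C)C)cc4)n[nH]c3n2)c1Cl` is the next step from compound 1: (2-(dimethylamino)ethyl)(methyl)amino in place of 4-methylpiperazin-1-yl on an aromatic carbon. The ring opens but the entering group keeps the same count of nitrogen and carbon atoms. The relevant comparisons are the steps from compound 1 to compounds 2 and 3: the loss of the second ring nitrogen cost a lot, whereas changing the alkyl on that nitrogen cost nothing. Since the group that enters still carries two nitrogen atoms, the expectation is a step of about a 2.4-fold higher number from compound 1 to compound 4 (0.37 log units; beyond the scatter) in this assay, within or only slightly beyond the scatter, toward a somewhat higher number. Compound 4 is therefore expected to give about 4 nM, with a likely range of 1 nM to 25 nM.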

Compound 4, half-maximal inhibitory concentration: 11 nM
The estimate for compound 4 lay 2.8-fold (0.44 log units) below the measured number; the measured number falls inside the stated range.
By their numbers in this assay, from the lowest: compounds 3 and 1 (each within the scatter of the next); then compound 4; then compound 2.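

In this assay, replacing 4-methylpiperazin-1-yl with the ring-free (2-(dimethylamino)ethyl)(methyl)amino gives a real but modest loss, a 6.5-fold higher number from compound 1 to compound 4 (0.81 log units; beyond the scatter), and the comparison with the isopropyl analogue reads similarly, a 7.9-fold higher number from compound 3 to compound 4 (0.90 log units; beyond the scatter). A ring alone does not account for the activity at this position on the aromatic ring: piperidin-1-yl has a ring and the entering group has none, yet a 51-fold lower number from compound 2 to compound 4 (1.71 log units; beyond the scatter), so the open chain recovers much of what piperidin-1-yl loses. No measurement available here bears on why these steps have the sizes they do.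

Still open, going by these compounds, is whether morpholin-4-yl, with an oxygen in place of the distal ring nitrogen, would stay near compound 1. Also open, on these data alone, is how a longer chain between the two amine nitrogens would compare with compound 4.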